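The source may report more compounds than this note shows. Statements on the series, on what has been measured and on what is new or still open speak of the compounds shown alone.

In an ADME assay on LLC-PK1 cells (Sus scrofa) for permeability (a lower number here means that the compound crosses the layer more slowly, a higher number that the compound crosses the layer faster), three compounds on one shared core have numbers. Compound 1 (`C#CCOc1cnc(C(=O)Nc2cc(F)c(F)c([C@@]3(C)N=C(N)S[C@@]4(COC)C[C@H]43)c2)c(C)c1`) gives 19 10^-6 cm/s as its result, compound 2 (`COC[C@]12C[C@H]1[C@@](C)(c1cc(NC(=O)c3cnc(OCC(F)(F)F)cn3)cc(F)c1F)N=C(N)S2`) gives 25 10^-6 cm/s and compound 3 (`COC[C@]12C[C@H]1[C@@](C)(c1cc(NC(=O)c3cnc(OCCC(F)(F)F)cn3)cc(F)c1F)N=C(N)S2`) gives 23 10^-6 cm/s as well, so compound 3 lies within the scatter of both others. Compound 4 (`CCCOc1cnc(C(=O)Nc2cc(F)c(F)c([C@@]3(C)N=C(N)S[C@@]4(COC)C[C@H]43)c2)cn1`) is still unmeasured. It differs from compound 3 at one place, by methyl in place of trifluoromethyl on a saturated chain carbon, two bonds along the chain from an oxygen on an aromatic ring in the side chain: methyl in place of trifluoromethyl on a saturated chain carbon, two bonds along the chain from an oxygen on an aromatic ring, so that 3,3,3-trifluoropropoxy becomes propoxy. Among the measured compounds shown here, one measured step touches the same chain, a 1.1-fold lower number from compound 2 to compound 3 (0.04 log units; within the scatter) for 2,2,2-trifluoroethyl in place of trifluoromethyl, and it stays within the scatter. For the measured compounds named here, no measured compound carries a chain without fluorine, so that step is only a loose guide. In this assay no change beyond the scatter is therefore expected, and the estimated 1.0-fold lower number from compound 3 to compound 4 (0.02 log units; within the scatter) is small. Compound 4 is estimated at 22 10^-6 cm/s with an expected range from 14 10^-6 cm/s to 34 10^-6 cm/s overall.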

Compound 4, apparent permeability: 18 10^-6 cm/s
Beside the measured number, compound 4's estimate is 1.2-fold (0.09 log units) above it; measured number inside the range.
By their numbers in this assay, from the lowest: compounds 4, 1, 3 and 2 (each within the scatter of the next).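

In this assay, the first chain without fluorine at this place stays level with its fluorinated counterpart: methyl in place of trifluoromethyl, on a saturated chain carbon two bonds along the chain from an oxygen on an aromatic ring, gives a 1.3-fold lower number from compound 3 to compound 4 (0.11 log units; within the scatter). The shorter fluorinated chain and the different aromatic amide group show the same picture, with a 1.4-fold lower number from compound 2 to compound 4 (0.14 log units; within the scatter) for ethyl in place of trifluoromethyl and a 1.1-fold lower number from compound 1 to compound 4 (0.02 log units; within the scatter) for 5-propoxypyrazin-2-yl in place of 3-methyl-5-(propargyloxy)pyridin-2-yl, so all four numbers lie within the scatter along these steps. No measurement is at hand that would explain these numbers.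

On these data alone, it remains open whether a longer chain such as pentyloxy would also stay within the scatter. The same question stands for an amine or a carboxylic acid at the end of the chain.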